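The source may report more compounds than this note shows. Statements on the series, on what has been measured and on what is new or still open speak of the compounds shown alone.

Compound 1 `CC(/N=c1\c(O)c(O)\c1=N/Cc1ccc(C#N)cc1Cl)C(C)(C)C` gives 180 nM in a functional assay for inhibition, with Rattus norvegicus as the target; on this read-out higher numbers stand for weaker inhibition and lower numbers for stronger inhibition. Compound 2 `CCC(C)(C)/N=c1\c(O)c(O)\c1=N/Cc1ccc(C#N)cc1Cl` gives 130 nM in this assay.

On these two numbers compound 2 stands lowest, yet the step of a 1.4-fold lower number from compound 1 to compound 2 (0.14 log units; within the scatter) lies within the scatter, so the pair cannot be ordered. Compound 3 `CCC(C)(C)/N=c1\c(O)c(O)\c1=N/Cc1ccc(C#N)cc1` differs from compound 2 by hydrogen in place of chloro on an aromatic carbon. Among the compounds with values here, the only measured step, a 1.4-fold lower number from compound 1 to compound 2 (0.14 log units; within the scatter), alters the group on the double-bonded nitrogen and not this ring, so no measured step bears on the change, and nothing here points to a shift beyond the scatter. Compound 3 is therefore expected to give about 200 nM in this assay, between 70 nM and 600 nM. That expectation amounts to a step of a 1.5-fold higher number from compound 2 to compound 3 (0.19 log units; within the scatter).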

Compound 3, half-maximal inhibitory concentration: 1100 nM
Compound 3: the middle estimate sits 5.5-fold (0.74 log units) below what was measured, and the stated range ends below it.
By their numbers in this assay, from the lowest: compounds 2 and 1 (each within the scatter of the next); then compound 3.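

In this assay the change from chloro to hydrogen gives an 8.5-fold higher number from compound 2 to compound 3 (0.93 log units; beyond the scatter) and so means weaker inhibition, whereas the earlier change on the double-bonded nitrogen stayed within the scatter. This aromatic carbon, ortho to a large group and meta to a cyano group, therefore matters more for this pair than that nitrogen substituent did for the first pair. No measured evidence here explains the loss. On these data alone, whether fluoro, bromo or methyl at this position would match chloro remains open. Also open, as far as these compounds go, is whether removing chloro costs as much with 1,2,2-trimethylpropyl on the nitrogen.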